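The compounds below may be only part of what the source reports. "The series", "measured", "known", "first", "only" and "open" are said of these compounds alone.

Compound 1, `CCCOc1nc(N)nc2c1ncn2/C=C1/CC1(CO)CO`, is measured in an ADME assay on HFF cells (Homo sapiens) for cytotoxicity, with a stated time of 8 days (on this read-out higher numbers stand for lower toxicity in this test and lower numbers for higher toxicity in this test), which reports only a limit for it: compound 1 gives > 300000 nM. Compound 2, `CCCCNc1nc(N)nc2c1ncn2/C=C1/CC1(CO)CO`, also reaches only a limit in this assay, at > 300000 nM. Compound 3, `CSc1nc(N)nc2c1ncn2/C=C1/CC1(CO)CO`, likewise gives > 300000 nM in this assay, again a limit rather than a number. The steps between these three compounds are therefore not readable in size: a step that the two limits leave unreadable from compound 1 to compound 2, a step that the two limits leave unreadable from compound 1 to compound 3 and a step that the two limits leave unreadable from compound 2 to compound 3. What the three share is shown by the limit of > 300000 nM in this assay, at which 3 of the 3 values shown sit.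

The compound to follow is compound 4, `C=CCOc1nc(N)nc2c1ncn2/C=C1/CC1(CO)CO`, which differs from compound 1 by vinyl in place of ethyl on a saturated chain carbon bound to an oxygen on an aromatic ring. This change at the chain bound to the aromatic oxygen is smaller than any of the measured steps on the aromatic carbon, and those steps themselves gave no readable size, so no direction beyond the scatter can be expected. Compound 4 is therefore expected to stand near compound 1, a step of a number no higher from compound 1 to compound 4 (the limit leaves the size open) in this assay, most likely again as a limit. The estimate for compound 4 in this assay is 300000 nM, within 100000 nM to 1000000 nM.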

Compound 4, half-maximal cytotoxic concentration: > 300000 nM
Compound 4 gave a limit, no number; the forecaster's own chance of this, stated with the estimate: 85%; the middle value lies on the limit itself.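

Compound 4 also gives only a limit in this assay, so its steps to compound 1, compound 2 and compound 3 cannot be read in size: the limit of > 300000 nM in this assay, at which 4 of the 4 values shown sit. The compounds shown leave open at what concentration any of them harms these cells, and whether their groups differ in this test at all.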